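Hydroxy to amino exchange carried onto a second core

A few compounds are considered here, and "the series" means these few. Any claim that something is new, unique, unknown or untested is made for them only; others in the source may bear on it.

Compound 1 `Oc1cccc(/C=C/c2cccc(O)c2)c1` and compound 2 `Nc1cccc(/C=C/c2cccc(O)c2)c1` share one core and differ by amino in place of hydroxy on an aromatic carbon. Within the data shown here, in a functional assay on MCF7 cells (Homo sapiens) for inhibition, read by MTT assay, with a stated time of 2 days (on this read-out higher numbers stand for weaker inhibition and lower numbers for stronger inhibition), compound 1 gives 21 ug/mL, and compound 2 gives 54 ug/mL; the step of a 2.6-fold higher number from compound 1 to compound 2 (0.41 log units; beyond the scatter) lies beyond the scatter and is the only measured instance of this exchange.

Compound 3 `COc1cccc(/C=C/c2ccc(O)cc2)c1` stands on a different core; the difference between the two cores is not broken down here. In this assay compound 3 gives 21 ug/mL, level with compound 1 at the digits given, and the gap to compound 2 is the same as that of compound 1.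

Compound 4 `COc1cccc(/C=C/c2ccc(N)cc2)c1` is not yet measured and differs from compound 3 by amino in place of hydroxy on an aromatic carbon. Among the measured compounds shown here, this is the same kind of change as the one from compound 1 to compound 2, not the same change: there the group sat meta to a group of 9 heavy atoms, here it sits para to a large group, and the surrounding core is different. For the measured compounds named here, no second measured pair shows whether the exchange behaves alike on another core or at another place, so the expectation rests on the single measured step.

Compound 4 is expected to give about 55 ug/mL in this assay, with a range of 25 ug/mL to 120 ug/mL. For compound 4 the expected step is a 2.6-fold higher number from compound 3 to compound 4 (0.42 log units; beyond the scatter). That size is taken from a 2.6-fold higher number from compound 1 to compound 2 (0.41 log units; beyond the scatter) because compound 3 gives 21 ug/mL, the same number at the digits given as compound 1.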

Compound 4, half-maximal inhibitory concentration: 52 ug/mL
Beside the measured number, compound 4's estimate is 1.1-fold (0.02 log units) above it; measured number inside the range.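

In this assay, amino in place of hydroxy gives a 2.5-fold higher number from compound 3 to compound 4 (0.39 log units; beyond the scatter), and this step matches the earlier one in direction and size, so within these two pairs the exchange carries from one core to the other without a detectable difference: the same change on two cores in this assay, a 2.6-fold higher number (0.41 log units; beyond the scatter) from compound 1 to compound 2 and a 2.5-fold higher number (0.39 log units; beyond the scatter) from compound 3 to compound 4, 1.0-fold (0.02 log units) apart, within the scatter of two such steps. Neither pair goes against this, and the hydroxy compound gives the lower number in both, so the earlier step served as a fair guide to the later one in this series. Among these compounds, the agreement rests on only two pairs, which differ both in the core and in where the exchanged group sits, with the amino of compound 4 para to a large group; it therefore cannot separate these two influences, does not explain the step, and does not establish a rule for cores beyond those of compound 1 and compound 3.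

From the compounds shown here alone, it remains open whether groups other than amino, such as a dimethylamino group, an acetamide or a carboxylic acid, would give a step of similar size at the same places on these two cores. Going by these compounds, it also remains open whether the step would hold on a core carrying a longer chain, such as ethoxy, in place of the methoxy of compound 3 and compound 4.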